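Swapping an Anilino Group for Piperidine on a Shared Core

This account rests on a few compounds, and the source may have more. Where it says the series, first, only, none or still open, it means among the compounds named here.

Three compounds share one core and differ only in the group on a double-bonded ring carbon. Compound 1 `O=C1C=C(Nc2ccc(I)cc2)C(=O)c2c1nc1n2[C@H]2OC[C@@H](O)[C@H]2OC1` gives 4070 nM in a functional assay on HeLa cells (Homo sapiens) for inhibition, read by sulforhodamine B assay; a higher number here means a weaker inhibitor, a lower number a stronger inhibitor. Compound 2 `Cc1ccc(NC2=CC(=O)c3nc4n(c3C2=O)[C@H]2OC[C@@H](O)[C@H]2OC4)cc1` gives 3860 nM in this assay, and compound 3 `Cc1ccc(NC2=CC(=O)c3c(nc4n3[C@H]3OC[C@@H](O)[C@H]3OC4)C2=O)cc1C` gives 4320 nM in this assay. Compound 3 has the highest of the three numbers, but its gaps to compound 1 and to compound 2 both lie within the scatter, so no order among the three can be claimed.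

Compound 4 `O=C1C(N2CCCCC2)=CC(=O)c2c1nc1n2[C@H]2OC[C@@H](O)[C@H]2OC1` is derived from compound 3 by piperidin-1-yl in place of (3,4-dimethylphenyl)amino on a double-bonded ring carbon. Within the data shown here, the only measured step, a 1.1-fold lower number from compound 1 to compound 2 (0.02 log units; within the scatter), changes just the group on an aromatic carbon and lay within the scatter; compound 4 instead loses the aromatic ring altogether, so that step does not bear on this change. Among the measured compounds shown here, no measured step speaks to it, and the direction remains open. Compound 4 is therefore estimated at 6000 nM, with a range from 1500 nM to 25000 nM. This estimate means an expected step of a 1.4-fold higher number from compound 3 to compound 4 (0.14 log units; within the scatter).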

Compound 4, half-maximal inhibitory concentration: > 16000 nM
Compound 4: a limit, no number; the forecaster's own chance of this, stated with the estimate: 15%; middle value at least 2.6-fold (0.42 log units) away from the limit.
By their numbers in this assay, from the lowest: compounds 2, 1 and 3 (each within the scatter of the next). At a limit, above all of these: compound 4.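

Compounds 1, 2 and 3 varied only the substituents on the anilino ring, and their numbers stayed within the scatter of one another, so they gave no sign that the double-bonded ring carbon was sensitive to change. Replacing the whole group shows that it is: piperidin-1-yl in place of (3,4-dimethylphenyl)amino gives an at least 3.7-fold higher number from compound 3 to compound 4 (0.56 log units; beyond the scatter) in this assay. The reading for compound 4 is a limit and not a number: the limit of > 16000 nM in this assay, at which 1 of the 4 values shown sits.

The change removes the aromatic ring and the hydrogen-bond donor together, so the compounds shown leave open which of the two the step follows. Going by these compounds, a cyclohexylamino group, with a hydrogen-bond donor on a non-aromatic ring, would separate them, and how far the number for compound 4 actually lies also remains open.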